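This account rests on a few compounds, and the source may have more. Where it says the series, first, only, none or still open, it means among the compounds named here.

Measured compounds:
- compound 1 `CC(C(=O)NCc1ccc(C(F)(F)F)nc1N(C)C)c1ccc(NS(C)(=O)=O)c(F)c1`: 2390 nM
- compound 2 `C[C@H](C(=O)NCc1ccc(C(F)(F)F)nc1N1CCC[C@H]1CO)c1ccc(NS(C)(=O)=O)c(F)c1`: "not active" (no number reported)
- compound 3 `C[C@H](C(=O)NCc1ccc(C(F)(F)F)nc1N1CCC(c2ccccc2)CC1)c1ccc(NS(C)(=O)=O)c(F)c1`: 17.4 nM

In a functional assay on CHO-K1 cells for antagonist activity at transient receptor potential cation channel subfamily V member 1 (Homo sapiens), read by FLIPR (on this read-out higher numbers stand for weaker inhibition and lower numbers for stronger inhibition), compound 1 gives 2390 nM, the highest of the two numbers reported. Its nearest neighbour, compound 3, gives 17.4 nM, a gap well beyond the scatter of this assay. Compound 2 gives "not active" (no number reported) and so no number at all; nothing more can be said of it here.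

Compound 4 `COC1CCN(c2nc(C(F)(F)F)ccc2CNC(=O)C(C)c2ccc(NS(C)(=O)=O)c(F)c2)CC1` is not yet measured. It differs from compound 1 in one place: 4-methoxypiperidin-1-yl in place of dimethylamino on an aromatic carbon. Within the data shown here, no step between measured compounds runs through exactly this change, so any expectation rests on what compound 1 and compound 3 show. Compound 3, which also carries a six-membered non-aromatic ring with 1 hetero atom on the same aromatic carbon, sits far below compound 1 in this assay, and the 4-methoxypiperidin-1-yl group of compound 4 shares that ring while lacking the phenyl of compound 3. A move downward beyond the scatter is therefore expected, though smaller than the gap from compound 1 to compound 3: the step from compound 1 to compound 4 is estimated at an 8.0-fold lower number from compound 1 to compound 4 (0.90 log units; beyond the scatter). Compound 4 is expected to give about 300 nM, within a range from 60 nM to 1500 nM.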

Compound 4, half-maximal inhibitory concentration: 280 nM
Compound 4: middle estimate off by 1.1-fold (0.03 log units), on the high side; measured number inside the range.
By their numbers in this assay, from the lowest: compound 3; then compound 4; then compound 1.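

Among these compounds, the step of an 8.5-fold lower number from compound 1 to compound 4 (0.93 log units; beyond the scatter) in this assay is the first change in one place that can be read at this aromatic carbon, next to the ring nitrogen. It shows that 4-methoxypiperidin-1-yl in place of dimethylamino moves the number beyond the scatter, and that this group does so without any phenyl on its six-membered ring. Nothing shown here gives a measured reason for this step.

From the compounds shown here alone, what an unsubstituted piperidin-1-yl or a morpholine ring would give on this carbon remains open. The ring and the methoxy group enter together in this step, and the data do not separate them. Also open, going by these compounds, is how a hydroxy group or a longer alkoxy chain in place of that methoxy group would read.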